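Truncating the triazole-capped alkyne chain to a terminal ethynyl

This account rests on a few compounds, and the source may have more. Where it says the series, first, only, none or still open, it means among the compounds named here.

Compound 1 `CNC(=O)[C@@]12C[C@@H]1[C@@H](n1cnc3c(NCc4cccc(Cl)c4)nc(C#CCCCCc4cn(-c5ccc(N)cc5)nn4)nc31)[C@H](O)[C@@H]2O` gives 3% in an assay on CHO cells for displacement of a labelled ligand from adenosine receptor A1 (Homo sapiens), read by scintillation counting, tested at 10 uM; on this read-out lower numbers stand for less inhibition and higher numbers for more inhibition at the one concentration tested (going by the name of the read-out).
Compound 2 `CNC(=O)[C@@]12C[C@@H]1[C@@H](n1cnc3c(NCc4cccc(Cl)c4)nc(C#CCCCCc4cn(CCCCN)nn4)nc31)[C@H](O)[C@@H]2O` gives 13%.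
Compound 3 `CNC(=O)[C@@]12C[C@@H]1[C@@H](n1cnc3c(NCc4cccc(Cl)c4)nc(C#CCCCCc4cn(CCNC(C)=O)nn4)nc31)[C@H](O)[C@@H]2O` gives 12%.

Compound 3 stands second highest of the three numbers, with compound 2 nearest and compound 1 furthest, both within the scatter. Compound 4 `C#CCCCCC#Cc1nc(NCc2cccc(Cl)c2)c2ncn([C@H]3[C@H](O)[C@H](O)[C@]4(C(=O)NC)C[C@H]34)c2n1` differs from compound 3 by ethynyl in place of 1-(2-acetamidoethyl)-1H-1,2,3-triazol-4-yl on a saturated chain carbon, four bonds along the chain from a triple-bonded carbon. The measured steps, a number 10 percentage points higher from compound 1 to compound 2 (within the scatter), a number 9 percentage points higher from compound 1 to compound 3 (within the scatter) and a number 1 percentage points lower from compound 2 to compound 3 (within the scatter), all alter only the group on the aromatic nitrogen of the triazole and all lie within the scatter, so none of them covers loss of the ring itself. With every measured change at this end of the chain leaving the number unmoved, compound 4 is expected to show no step beyond the scatter, a number 2 percentage points lower from compound 3 to compound 4 (within the scatter). Compound 4 is therefore estimated at 10%, between 0% and 25%.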

Compound 4, a percentage reported as inhibition, at one concentration (the size of the read-out at that concentration, not a potency): 31%
The estimate for compound 4 lay 21 percentage points below the measured number; the measured number lies above the stated range.
By their numbers in this assay, from the lowest: compounds 1, 3 and 2 (each within the scatter of the next); then compound 4.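

In this assay only loss of the whole triazole moves the number, where changes to the group on its nitrogen did not: ethynyl in its place gives a number 19 percentage points higher from compound 3 to compound 4 (beyond the scatter) and a number 18 percentage points higher from compound 2 to compound 4 (beyond the scatter) and a number 28 percentage points higher from compound 1 to compound 4 (beyond the scatter) as modest steps. This end of the chain therefore responds to the ring and its substituent being replaced together, and not to the substituent alone. Nothing given here accounts for these steps.

The compounds shown leave open whether the terminal ethynyl itself matters or merely the absence of the triazole. A primary amine or a carboxylic acid placed directly on the same chain would separate these two readings.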